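Trifluoromethyl for Nitrile on a Weakly Active Core

The source may hold more compounds than are shown below. What is called first, only, known or untested is meant among the compounds shown, and "the series" means these compounds.

Compound 1 `COC(=O)c1sc2cc(-c3cccs3)cnc2c1N` gives 26900 nM in a functional assay on MCF7 cells (Homo sapiens) for inhibition, read by sulforhodamine B assay, with a stated time of 48 h; a higher number here means a weaker inhibitor of growth, a lower number a stronger inhibitor of growth.
Compound 2 `COC(=O)c1sc2cc(-c3ccc(F)nc3)cnc2c1N` has no result in this assay, "not determined" (no result reported).
Compound 3 `COC(=O)c1sc2cc(-c3ccc(C#N)cc3)cnc2c1N` gives > 75000 nM in this assay, which is a limit of the assay and not a number.

Compound 3 therefore stands at the top edge of what this assay can report; the shown evidence is the limit of > 75000 nM in this assay, at which 1 of the 3 values shown sits, and among the three entries only compound 1 carries a single number, which itself marks a weak inhibitor of growth. Compound 4 `COC(=O)c1sc2cc(-c3ccc(C(F)(F)F)cc3)cnc2c1N` differs from compound 3 in one place: trifluoromethyl in place of cyano on an aromatic carbon. Among the compounds with values here, no measured pair in this set separates this change, so its size in this assay cannot be read from a neighbouring step. With compound 3 already at the limit, the expected step is small, no further than the scatter of repeated measurements in either direction, and compound 4 is expected to remain a weak inhibitor of growth. The estimate for compound 4 is 70000 nM, in the range 20000 nM to 150000 nM, which means an expected step of an at least 1.0-fold lower number from compound 3 to compound 4 (0.02 log units; that floor lies within the scatter), with a real chance that this assay again reports only a limit.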

Compound 4, concentration for 50% growth inhibition: > 150000 nM
Compound 4 ended at the assay's limit (the forecaster's own chance of this, stated with the estimate: 60%); middle value at least 2.1-fold (0.33 log units) away from the limit.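

In this assay, within the data shown here, compound 3 and compound 4 each give only a limit of the assay and not a number, so no step between them can be read. The compounds shown leave open what size of change, if any, trifluoromethyl in place of cyano brings to growth inhibition.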